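This account rests on a few compounds, and the source may have more. Where it says the series, first, only, none or still open, it means among the compounds named here.

Working notes on the series.

The shared core of compound 1 `O=C(Nn1c(-c2cccc([N+](=O)[O-])c2)nc2c(-c3ccco3)n[nH]c2c1=O)c1cccnc1` carries a furan-2-yl group; in a functional assay on SK-OV-3 cells (Homo sapiens) for cytotoxicity, read by sulforhodamine B assay, with a stated time of 2 days, tested at 100 uM (a lower number here means less inhibition, a higher number more inhibition at the concentration tested (going by the name of the read-out)), compound 1 gives -0.61%, essentially no inhibition at the tested concentration. Compound 2 `O=C(Nn1c(-c2cccc([N+](=O)[O-])c2)nc2c(-c3cccs3)n[nH]c2c1=O)c1cccnc1` bears thiophen-2-yl in the corresponding place, but in this assay compound 2 gives "not determined" (no result reported), so compound 2 stands without a number of its own, and nothing can be said about how compound 2 compares with compound 1 in this assay.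

Compound 3 `O=C(Nn1c(-c2cccc([N+](=O)[O-])c2)nc2c(CCc3ccccc3)n[nH]c2c1=O)c1cccnc1` is the next member to be measured in this assay. The change from compound 2 to compound 3 is phenethyl in place of thiophen-2-yl on an aromatic carbon. Since compound 2 has no value, no step from compound 2 can be computed, and no difference between compound 1 and compound 3 is listed either. The only anchor is the near-zero reading of compound 1 in this assay, so for compound 3 the expectation is again a small effect, with no step in either direction beyond the usual scatter of this kind of measurement. For compound 3 the estimated inhibition in this assay is 5%, expected to lie between -10% and 25%.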

Compound 3, a percentage reported as inhibition, at one concentration (the size of the read-out at that concentration, not a potency): 30.2%
The estimate for compound 3 lay 25.2 percentage points below the measured number; measured number outside the range, above it.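

Phenethyl in place of furan-2-yl gives a number 30.8 percentage points higher from compound 1 to compound 3 (beyond the scatter) in this assay, so the reading responds to the group carried on this aromatic carbon, which the near-zero reading of compound 1 alone could not show. Among these compounds, the change brings in a six-membered aromatic ring of carbon only, held on a chain, and this is the first sign that the series can register inhibition at the tested concentration through this place, although the number is the size of an effect at that one concentration and not a potency. Nothing available explains why compound 3 reads higher than compound 1.

From the compounds shown here alone, compound 3 differs from compound 1 in both its ring and its chain, so it remains open which of the two carries the gain, and the step from compound 2 cannot be read. A benzyl group, a longer chain ending in phenyl, or a phenethyl group bearing an amine or a carboxylic acid at this place would show how far the effect follows the chain, the ring or a substituent on it.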